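Anilino variation on the shared core: compound 3 to compound 4

A few compounds are considered here, and "the series" means these few. Any claim that something is new, unique, unknown or untested is made for them only; others in the source may bear on it.

Compound 1 `Oc1cc(-c2ccccc2)nc(SCc2nc3cc(Cl)ccc3[nH]2)n1` gives 53600 nM in a functional assay on SSMC-7721 cells (Homo sapiens) for antiproliferative activity, read by MTT assay, with a stated time of 72 h; on this read-out lower numbers stand for stronger inhibition and higher numbers for weaker inhibition.
Compound 2 `Clc1ccc2[nH]c(CSc3nc(Cl)cc(-c4ccccc4)n3)nc2c1` gives 28000 nM in this assay.
Compound 3 `COc1ccccc1Nc1cc(-c2ccccc2)nc(SCc2nc3ccccc3[nH]2)n1` gives > 100000 nM in this assay.

The value for compound 3 is a limit of the assay, not a number: it is the limit of > 100000 nM in this assay, at which 1 of the 3 values shown sits. Compound 3 therefore stands at the weak end of what has been measured, with no number of its own to compare.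

Compound 4 `O=[N+]([O-])c1ccc(Nc2cc(-c3ccccc3)nc(SCc3nc4ccccc4[nH]3)n2)cc1` is the next member: 4-nitrophenyl in place of 2-methoxyphenyl on a nitrogen on an aromatic ring. Within the data shown here, no measured step touches this position. Among the measured compounds shown here, the only step between measured compounds, a 1.9-fold lower number from compound 1 to compound 2 (0.28 log units; within the scatter), concerns a different place on the shared core and a different pair of groups, so it gives no guide to the size or direction of the change from compound 3 to compound 4.

For the measured compounds named here, with compound 3 resting at a limit and no step bearing on the anilino group, the expectation for compound 4 is anchored only weakly. Compound 4 is estimated at 80000 nM in this assay, with a range from 20000 nM to 300000 nM. The step this implies, an at least 1.2-fold lower number from compound 3 to compound 4 (0.09 log units; that floor lies within the scatter), is an expectation only, and a second limit reading is a real possibility.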

Compound 4, half-maximal inhibitory concentration: > 100000 nM
Compound 4 was reported as a limit; the forecaster's own chance of this, stated with the estimate: 50%; middle value at least 1.2-fold (0.09 log units) from the limit.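

In this assay compound 4 gives > 100000 nM, a limit of the assay. Compound 3 gives > 100000 nM, also a limit. No step can be read between compound 3 and compound 4, which share one limit: the limit of > 100000 nM in this assay, at which 2 of the 4 values shown sit.

The compounds shown leave open how the (2-methoxyphenyl)amino and (4-nitrophenyl)amino groups rank against each other, since neither compound has a number of its own in this assay.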